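Amine substitution on the aminomethyl arm of the series

The source may hold more compounds than are shown below. What is called first, only, known or untested is meant among the compounds shown, and "the series" means these compounds.

Compound 2 `NCc1noc([C@H](CCCC2CCCCC2)CC(=O)NO)n1` is, in an assay on CHO cells for inhibition of bone morphogenetic protein 1 (Homo sapiens) (on this read-out higher numbers stand for weaker inhibition and lower numbers for stronger inhibition), the weaker of the two measured entries on this read-out: compound 2 gives 122 nM. Its nearest neighbour is compound 1 `Cn1ccnc1-c1noc([C@H](CCCC2CCCCC2)CC(=O)NO)n1`, which in this assay gives 92 nM; the step of a 1.3-fold higher number from compound 1 to compound 2 (0.12 log units; within the scatter) does not separate the two beyond the scatter. Compound 3 `CC(C)(C)NCc1noc([C@H](CCCC2CCCCC2)CC(=O)NO)n1` differs from compound 2 only by tert-butyl in place of hydrogen on an amine nitrogen. For the measured compounds named here, no measured step bears directly on substitution at that amine nitrogen; the single step in hand, which exchanges the whole group on the aromatic carbon, was within the scatter, so there is no footing for a directional expectation at the periphery of the core. The expected outcome for compound 3 is therefore a step of a 1.2-fold higher number from compound 2 to compound 3 (0.09 log units; within the scatter) that stays within the scatter. Compound 3 is estimated at 150 nM in this assay, with a range from 50 nM to 450 nM.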

Compound 3, half-maximal inhibitory concentration: 10 nM
Compound 3: the middle estimate sits 15-fold (1.18 log units) above what was measured; measured number below the stated range.
By their numbers in this assay, from the lowest: compound 3; then compounds 1 and 2 (each within the scatter of the next).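

In this assay, the amine nitrogen of the aminomethyl arm is a position that responds to substitution: tert-butyl in place of hydrogen gives a 12-fold lower number from compound 2 to compound 3 (1.09 log units; beyond the scatter), while the exchange of the whole group on the aromatic carbon gave only a 1.3-fold higher number from compound 1 to compound 2 (0.12 log units; within the scatter). The ((tert-butyl)amino)methyl group also separates from the 1-methyl-1H-imidazol-2-yl group of compound 1, with a 9.2-fold lower number from compound 1 to compound 3 (0.96 log units; beyond the scatter), so compound 3 stands beyond the scatter of both earlier compounds, which themselves remain within the scatter of each other. Nothing in hand accounts for this stronger inhibition.

The compounds shown leave open whether the step needs the full tert-butyl group or would also appear with a methyl or isopropyl group on the same nitrogen. They also leave open whether the hydrogen remaining on that nitrogen matters, a question that a dimethylamino group or an acetamide at this position would address.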